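A morpholine swap and the step it may bring

The source may report more compounds than this note shows. Statements on the series, on what has been measured and on what is new or still open speak of the compounds shown alone.

Measured in a functional assay on PC-3 cells (Homo sapiens) for inhibition, read by MTT assay, with a stated time of 48 h; on this read-out lower numbers stand for stronger inhibition and higher numbers for weaker inhibition:
compound 1 `COc1ccc(-c2coc3cc(OCCCBr)ccc3c2=O)cc1`: 62600 nM
compound 2 `CCN1CCN(C(=S)SCCCOc2ccc3c(=O)c(-c4ccc(OC)cc4)coc3c2)CC1`: 7080 nM
compound 3 `COc1ccc(-c2coc3cc(OCCCSC(=S)N4CCN(c5ccccn5)CC4)ccc3c2=O)cc1`: 17400 nM

In this assay, compound 3 holds the middle of the three numbers, higher than compound 2 and lower than compound 1. Compound 4 `COc1ccc(-c2coc3cc(OCCCSC(=S)N4CCOCC4)ccc3c2=O)cc1` has morpholin-4-yl in place of 4-(pyridin-2-yl)piperazin-1-yl on a thiocarbonyl carbon. Among the measured compounds shown here, two measured steps bear on this change. Replacing bromine with a whole sulfur-bearing group gave an 8.8-fold lower number from compound 1 to compound 2 (0.95 log units; beyond the scatter). The closer guide is a 2.5-fold higher number from compound 2 to compound 3 (0.39 log units; beyond the scatter), a modest change made within that same group. No step beyond the scatter is therefore expected, only a 1.5-fold lower number from compound 3 to compound 4 (0.16 log units; within the scatter). The estimate for compound 4 is 12000 nM, with an expected range of 5000 nM to 35000 nM.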

Compound 4, half-maximal inhibitory concentration: 27400 nM
Estimate against measurement, compound 4: 2.3-fold (0.36 log units) below; the range from low to high includes it.
By their numbers in this assay, from the lowest: compound 2; then compounds 3 and 4 (each within the scatter of the next); then compound 1.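

In this assay, the smaller morpholin-4-yl on the thiocarbonyl carbon gives a 1.6-fold higher number from compound 3 to compound 4 (0.20 log units; within the scatter) so the pyridin-2-yl-bearing group and morpholin-4-yl cannot be told apart here. The group at this place still matters, with a 3.9-fold higher number from compound 2 to compound 4 (0.59 log units; beyond the scatter) when morpholin-4-yl replaces 4-ethylpiperazin-1-yl, while the whole morpholine-bearing group in place of bromine gives a 2.3-fold lower number from compound 1 to compound 4 (0.36 log units; beyond the scatter) as a modest step. Nothing measured here explains these differences. Still open, going by these compounds, is whether a 4-methylpiperazin-1-yl or a piperidin-1-yl on the thiocarbonyl carbon would match or pass compound 2 in this cell test.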